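The source may hold more compounds than are shown below. What is called first, only, known or untested is meant among the compounds shown, and "the series" means these compounds.

In a functional assay on A549 cells (Homo sapiens) for antiproliferative activity, read by MTT assay, with a stated time of 72 h (a higher number here means a weaker inhibitor, a lower number a stronger inhibitor), compound 1 `CCOc1cccc(-c2ncnn2-c2cc(OC)c(OC)c(OC)c2)c1` gives > 10000 nM, which is a limit of the assay and not a number. Compound 2 `COc1cc(-n2ncnc2-c2cccc([N+](=O)[O-])c2)cc(OC)c1OC` gives > 10000 nM in this assay, and this too is a limit. Compound 2 therefore has no number of its own, and the record so far is the limit of > 10000 nM in this assay, at which 2 of the 2 values shown sit.

Compound 3 `COc1cc(-n2ncnc2-c2cccc(F)c2)cc(OC)c1OC` differs from compound 2 by fluoro in place of nitro on an aromatic carbon, meta to a large group. For the measured compounds named here, only one measured step bears on this change, a step that the two limits leave unreadable from compound 1 to compound 2, which is also a swap of one group for another on an aromatic carbon. Its size cannot be read, so it offers no measured size to carry over, and neither of the two groups tried so far has produced a number in this assay. The expectation rests on that step alone, and it points to no gain beyond the scatter, although a number just inside the limit remains possible. The estimate means a step of a number no higher from compound 2 to compound 3 (the limit leaves the size open), which is expected to be no larger than the scatter. Compound 3 is expected at 10000 nM, with an estimated range of 2500 nM to 40000 nM.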

Compound 3, half-maximal inhibitory concentration: > 10000 nM
Compound 3: only a limit was reported; the forecaster's own chance of this, stated with the estimate: 70%; the middle value sits exactly at the limit.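

Compound 3 gives > 10000 nM in this assay, which is a limit of the assay and not a number. The steps reaching compound 3 from compound 1 and from compound 2 therefore cannot be read. The record now stands at: the limit of > 10000 nM in this assay, at which 3 of the 3 values shown sit.

The compounds shown leave open how strongly any of them acts, and whether any group on this aromatic carbon would give a readable number.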